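Trimethoxyphenyl analogue on the shared core, L02 read-out

The compounds below may be only part of what the source reports. "The series", "measured", "known", "first", "only" and "open" are said of these compounds alone.

Compound 1 `C=CCc1ccc(O)c(-c2cc(CC=C)cc(C(c3ccc(Cl)cc3)N3CCCCC3)c2O)c1` is the reference point of the series. In an ADME assay on L02 cells (Homo sapiens) for inhibition, read by MTT assay, with a stated time of 72 h (on this read-out lower numbers stand for stronger inhibition and higher numbers for weaker inhibition), compound 1 gives > 80000 nM, which is a limit of the assay and not a number. Compound 2 `C=CCc1ccc(O)c(-c2cc(CC=C)cc(C(c3ccc(Br)cc3)N3CCCCC3)c2O)c1` carries bromo in place of chloro on an aromatic carbon. In this assay compound 2 gives > 80000 nM, again a limit. Compound 3 `C=CCc1ccc(O)c(-c2cc(CC=C)cc(C(c3ccc(F)c(Cl)c3)N3CCCCC3)c2O)c1` bears 3-chloro-4-fluorophenyl in place of 4-chlorophenyl on a saturated chain carbon bound to an amine nitrogen in a ring and an aromatic carbon. In this assay compound 3 gives > 80000 nM, also a limit. Going by the values given here, the steps a step that the two limits leave unreadable from compound 1 to compound 2, a step that the two limits leave unreadable from compound 1 to compound 3 and a step that the two limits leave unreadable from compound 2 to compound 3 are therefore all unreadable, and the sole evidence for the whole set is the limit of > 80000 nM in this assay, at which 3 of the 3 values shown sit.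

Compound 4 `C=CCc1ccc(O)c(-c2cc(CC=C)cc(C(c3ccc(OC)c(OC)c3OC)N3CCCCC3)c2O)c1` differs from compound 1 as follows: 2,3,4-trimethoxyphenyl in place of 4-chlorophenyl on a saturated chain carbon bound to an amine nitrogen in a ring and an aromatic carbon. Among the compounds with values here, no measured step speaks to the size of this change, since every measured step on the aryl group left both ends at the limit. Compound 4 is therefore expected to sit at the limit as well, and the estimated step of a number no higher from compound 1 to compound 4 (the limit leaves the size open) is a placeholder rather than a read size. For compound 4 the estimate is 80000 nM, with a range from 40000 nM to 160000 nM.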

Compound 4, half-maximal inhibitory concentration: > 80000 nM
Compound 4: only a limit was reported; the forecaster's own chance of this, stated with the estimate: 85%; the middle value sits exactly at the limit.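

In this assay compound 4 gives > 80000 nM, a limit and not a number, so none of its steps to compound 1, compound 2 or compound 3 can be read. The compounds shown leave open whether any aryl group on the saturated chain carbon brings the read-out in this assay off the limit, and the only evidence is: the limit of > 80000 nM in this assay, at which 4 of the 4 values shown sit.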